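Swapping iodo for butoxy: an estimate for compound 4

A few compounds are considered here, and "the series" means these few. Any claim that something is new, unique, unknown or untested is made for them only; others in the source may bear on it.

Compound 1 `CCn1c(=O)c2nc(-c3ccc(S(=O)(=O)N4CCOCC4)cc3)[nH]c2n(CC)c1=O`: 13 nM
Compound 2 `CCn1c(=O)c2nc(-c3ccc(S(=O)(=O)N4CCSCC4)cc3)[nH]c2n(CC)c1=O`: 36.6 nM
Compound 3 `Cn1c(=O)c2nc(-c3ccc(I)cc3)[nH]c2n(C)c1=O`: 1.3 nM

Of the compounds shown here, three sharing one core have been measured in an assay for binding affinity to adenosine receptor A1 (Bos taurus); on this read-out lower numbers stand for stronger inhibition and higher numbers for weaker inhibition. Compound 3 gives 1.3 nM, the lowest number of the three. Its nearest neighbour is compound 1, which gives 13 nM in this assay, and the furthest is compound 2 at 36.6 nM in this assay. Going by the values given here, the only single-point step between measured compounds runs from compound 1 to compound 2: a 2.8-fold higher number from compound 1 to compound 2 (0.45 log units; beyond the scatter).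

The unmeasured compound 4 `CCCCOc1ccc(-c2nc3c(=O)n(C)c(=O)n(C)c3[nH]2)cc1` is derived from compound 3 by one change, (butoxy in place of iodo on an aromatic carbon), that is, butoxy in place of iodo on an aromatic carbon, para to a large group. Among the compounds with values here, no measured step touches this iodo position; the one measured step concerns a ring on the sulfonyl sulfur and therefore bears only indirectly on the present change, showing that a modest exchange of one group for another on this ring can move the number by a modest amount. Within the data shown here, with no direct precedent, a modest rise in the number is expected, and the step from compound 3 to compound 4 in this assay is estimated as a 4.6-fold higher number from compound 3 to compound 4 (0.66 log units; beyond the scatter). For compound 4 the expected value in this assay is 6 nM, within a range from 1.5 nM to 25 nM.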

Compound 4, half-maximal inhibitory concentration: 4 nM
The estimate for compound 4 lay 1.5-fold (0.18 log units) above the measured number; low and high end bracket the measured number.
By their numbers in this assay, from the lowest: compound 3; then compound 4; then compound 1; then compound 2.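

In this assay, going by these compounds alone, the exchange of iodo for butoxy gives a 3.1-fold higher number from compound 3 to compound 4 (0.49 log units; beyond the scatter) and provides the first direct reading at this position, on an aromatic carbon para to a large group. The step is modest, though beyond the usual scatter, even though the group grows from iodo with 1 heavy atom to butoxy with 5 heavy atoms and gains a hydrogen-bond acceptor, so this position accepts a much larger group at the cost of only a modest rise in the number. Nothing measured here explains why the number rises with this change.

The compounds shown cannot separate the part played by the oxygen from that of the chain, and a methoxy group, a plain butyl chain or a longer alkoxy chain at the same carbon would begin to tell these apart. From the compounds shown here alone, it also remains open how an amine or a carboxylic acid would fare at this position, and whether butoxy would produce a similar step on a core carrying ethyl groups like that of compound 1.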